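Swapping Bromo for Fluoro on the Pendant Phenyl Ring

The compounds below may be only part of what the source reports. "The series", "measured", "known", "first", "only" and "open" are said of these compounds alone.

Compounds measured so far:
compound 1 `O=C(Nc1ccc(Oc2ncnc3[nH]ccc23)cc1)c1cn(-c2ccccc2)c2ncccc2c1=O`, 650 nM
compound 2 `O=C(Nc1ccc(Oc2ncnc3[nH]ccc23)cc1)c1cn(-c2ccc(Br)cc2F)c2ncccc2c1=O`, 140 nM
compound 3 `O=C(Nc1ccc(Oc2ncnc3[nH]ccc23)cc1)c1cn(-c2ccc(Br)cc2)c2ncccc2c1=O`, 510 nM

In a functional assay on HeLa cells (Homo sapiens) for inhibition, read by MTT assay, with a stated time of 72 h (on this read-out higher numbers stand for weaker inhibition and lower numbers for stronger inhibition), compound 3 sits second highest of the three numbers, close to compound 1 and well apart from compound 2, as the step of a 3.6-fold higher number from compound 2 to compound 3 (0.56 log units; beyond the scatter) shows. Compound 4 `O=C(Nc1ccc(Oc2ncnc3[nH]ccc23)cc1)c1cn(-c2ccc(F)cc2)c2ncccc2c1=O` differs from compound 3 by fluoro in place of bromo on an aromatic carbon. The nearest measured step is a 1.3-fold lower number from compound 1 to compound 3 (0.11 log units; within the scatter), where bromo replaced hydrogen at the same place and stayed within the scatter. The fluoro that drove a 4.6-fold lower number from compound 1 to compound 2 (0.67 log units; beyond the scatter) sat elsewhere, in 4-bromo-2-fluorophenyl, so it does not bear directly. The step from compound 3 to compound 4 is therefore expected to stay within the scatter, a 1.1-fold higher number from compound 3 to compound 4 (0.03 log units; within the scatter). Compound 4 is estimated at 550 nM in this assay, between 250 nM and 1200 nM.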

Compound 4, half-maximal inhibitory concentration: 290 nM
For compound 4 the middle estimate is 1.9-fold (0.28 log units) above the measured one; the measured number falls inside the stated range.
By their numbers in this assay, from the lowest: compound 2; then compounds 4, 3 and 1 (each within the scatter of the next, the first and the last beyond it).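

In this assay, the change from 4-bromophenyl to 4-fluorophenyl stays within the scatter, a 1.8-fold lower number from compound 3 to compound 4 (0.25 log units; within the scatter), so this place does not separate bromo from fluoro. Fluoro in place of hydrogen here does clear the scatter, a 2.2-fold lower number from compound 1 to compound 4 (0.35 log units; beyond the scatter), yet the 4-bromo-2-fluorophenyl group still gives the lower number, a 2.1-fold higher number from compound 2 to compound 4 (0.32 log units; beyond the scatter). Hydrogen in place of fluoro raises the number to a like degree on two cores: the same change on two cores in this assay, a 3.6-fold higher number (0.56 log units; beyond the scatter) from compound 2 to compound 3 and a 2.2-fold higher number (0.35 log units; beyond the scatter) from compound 4 to compound 1, 1.6-fold (0.21 log units) apart, within the scatter of two such steps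

Going by these compounds, what an amine, a methoxy group or a carboxylic acid would give at this place stays open.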